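Replacing the Pyrazolyl Sulfonamide with a Trifluoroacetamide

This account rests on a few compounds, and the source may have more. Where it says the series, first, only, none or still open, it means among the compounds named here.

Measured compounds:
Compound 1 `Cn1cc(S(=O)(=O)Nc2ccc(Cc3nc4c([nH]3)c(=O)n(Cc3ccccc3F)c(=O)n4CC3CC3)cc2)cn1`: 390 nM
Compound 2 `Cc1nn(C)cc1S(=O)(=O)Nc1ccc(Cc2nc3c([nH]2)c(=O)n(Cc2ccccc2F)c(=O)n3CC2CC2)cc1`: 240 nM

In an assay on isolated protein for inhibition of phosphoenolpyruvate carboxykinase, cytosolic [GTP] (Homo sapiens) (a higher number here means a weaker inhibitor, a lower number a stronger inhibitor), compound 2 holds the lowest of the two numbers, yet the step of a 1.6-fold lower number from compound 1 to compound 2 (0.21 log units; within the scatter) lies within the scatter. Compound 3 `O=C(Nc1ccc(Cc2nc3c([nH]2)c(=O)n(Cc2ccccc2F)c(=O)n3CC2CC2)cc1)C(F)(F)F` differs from compound 2 by (trifluoromethyl)carbonyl in place of (1,3-dimethyl-1H-pyrazol-4-yl)sulfonyl on a nitrogen on an aromatic ring. Among the measured compounds shown here, the only measured step touches the leaving group itself and changed little; no measurement speaks to removing that group entirely. Compound 3 is nonetheless expected to give a weaker result, a step of a 3.3-fold higher number from compound 2 to compound 3 (0.52 log units; beyond the scatter), with an estimate of 800 nM and a range from 250 nM to 3000 nM.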

Compound 3, half-maximal inhibitory concentration: 1800 nM
Compound 3: middle estimate off by 2.3-fold (0.35 log units), on the low side; the measured number falls inside the stated range.
By their numbers in this assay, from the lowest: compounds 2 and 1 (each within the scatter of the next); then compound 3.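

Where the earlier step only added a methyl on the ring and stayed within the scatter, exchanging the whole sulfonyl group registers in this assay: putting (trifluoromethyl)carbonyl on this nitrogen gives a modest loss (a 7.5-fold higher number from compound 2 to compound 3 (0.88 log units; beyond the scatter)) and a similar one (a 4.6-fold higher number from compound 1 to compound 3 (0.66 log units; beyond the scatter)). The position therefore responds to this change, yet the loss of the ring-bearing group does not abolish inhibition. Nothing available explains the difference.

As far as these compounds go, the five-membered aromatic ring and the sulfonyl link leave together, so their shares remain open. Methanesulfonyl or acetyl on this nitrogen, or the free amine, would separate them.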